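The compounds below may be only part of what the source reports. "The series", "measured", "known", "first", "only" and "open" are said of these compounds alone.

In a functional assay on HL-60 cells (Homo sapiens) for cytotoxicity, read by CCK-8 assay, with a stated time of 24 h (on this read-out higher numbers stand for weaker inhibition and lower numbers for stronger inhibition), compound 1 `C=CC(=O)N1C(=O)CC(c2ccc(C)cc2)Sc2ccccc21` gives 94400 nM. Compound 2 `C=CC(=O)N1C(=O)CC(c2ccccc2Cl)Sc2ccccc21` gives 91400 nM, and compound 3 `C=CC(=O)N1C(=O)CC(c2ccccc2C(F)(F)F)Sc2ccccc21` gives 96400 nM. These three numbers all lie within the scatter of one another, so compound 1 holds no distinct rank among them.

Compound 4 `C=CC(=O)N1C(=O)CC(c2ccc([N+](=O)[O-])cc2)Sc2ccccc21` has not yet been measured. It differs from compound 1 by nitro in place of methyl on an aromatic carbon, para to a large group.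

For the measured compounds named here, no measured step makes this exact change, and no measured compound carries nitro, so the evidence is indirect. Going by the values given here, two steps bear on it. The first is a 1.0-fold lower number from compound 1 to compound 2 (0.01 log units; within the scatter), in which the substituted phenyl group changes. The second is a 1.1-fold higher number from compound 2 to compound 3 (0.02 log units; within the scatter), in which one group on an aromatic carbon replaces another. Both steps lie within the scatter. Going by these compounds, on the strength of these two small steps, no step beyond the scatter is expected in this assay, in either direction, although the nitro group remains untested here.

For compound 4 the estimated value is 88000 nM, within an expected range from 42000 nM to 150000 nM. This estimate means an expected 1.1-fold lower number from compound 1 to compound 4 (0.03 log units; within the scatter).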

Compound 4, half-maximal inhibitory concentration: 107000 nM
The estimate for compound 4 lay 1.2-fold (0.08 log units) below the measured number; measured number inside the range.
By their numbers in this assay, from the lowest: compounds 2, 1, 3 and 4 (each within the scatter of the next).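

In this assay, nitro in place of methyl on an aromatic carbon, para to a large group, gives a 1.1-fold higher number from compound 1 to compound 4 (0.05 log units; within the scatter) and so stays within the scatter. For the compounds shown here, this is the first step that changes only the group at this place, and it shows that a swap from methyl, with no hydrogen-bond acceptors, to nitro, which carries them, does not separate compound 4 from compound 1 on this read-out. The compounds and measurements shown offer no evidence that would explain why the number holds so steady across this change.

Going by these compounds, whether an amine, a carboxylic acid or a longer chain at this place would give a step beyond the scatter remains open, since only methyl and nitro have been compared here in a single step. On these data alone, it is also open whether a change to the shared core, rather than to the groups on its phenyl ring, would set any compound apart from the others in this assay.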